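Removing bromine from a thiazole amide with no measured activity yet

A few compounds are considered here, and "the series" means these few. Any claim that something is new, unique, unknown or untested is made for them only; others in the source may bear on it.

Compound 1 `Brc1nc2ccccc2[se]1` in a functional assay on NCI-H522 cells (Homo sapiens) for cytotoxicity, with a stated time of 3 days (a higher number here means a weaker inhibitor, a lower number a stronger inhibitor), gives > 40000 nM, a limit of the assay. Compound 2 `C#CCNC(=O)c1csc(Br)n1` in this assay gives > 40000 nM, again a limit. Compound 3 `c1ccc2[se]cnc2c1` in this assay gives > 40000 nM, also a limit.

Compound 1 and compound 3 are linked by a single change, (hydrogen in place of bromo on an aromatic carbon), and the step that the two limits leave unreadable from compound 1 to compound 3 cannot be read, because the limit of > 40000 nM in this assay, at which 3 of the 3 values shown sit, covers both ends of it. How the core of compound 1 relates to the core of compound 2 is not broken down here.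

Compound 4 `C#CCNC(=O)c1cscn1` is not yet measured. It differs from compound 2 by hydrogen in place of bromo on an aromatic carbon. This is the same kind of change as that from compound 1 to compound 3, but not the same: in compound 1 the carbon sits in a five-membered aromatic ring with one nitrogen and one selenium, part of a fused or bridged system of two rings, whereas in compound 2 it sits in a five-membered aromatic ring with one nitrogen and one sulfur, two ring bonds from the ring atom that bears a group of six heavy atoms.

For compound 4 the expected step is a step that the limit leaves unreadable from compound 2 to compound 4 in this assay, which rests on compound 2 giving > 40000 nM and on the measured pair showing no readable movement. Compound 4 is therefore estimated at 60000 nM, between 20000 nM and 200000 nM, most likely reported only as a limit.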

Compound 4, half-maximal inhibitory concentration: > 40000 nM
Compound 4: only a limit was reported; the forecaster's own chance of this, stated with the estimate: 85%; the middle value lies beyond the limit too.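

In this assay compound 4 gives > 40000 nM, which is a limit of the assay. The step from compound 2 to compound 4 therefore cannot be read, and the reason lies in both ends sitting at the same limit: the limit of > 40000 nM in this assay, at which 4 of the 4 values shown sit.

The compounds shown leave open whether hydrogen in place of bromo on an aromatic carbon changes the result in this assay on either core, and what number any of the four compounds would give.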